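A few compounds are considered here, and "the series" means these few. Any claim that something is new, unique, unknown or untested is made for them only; others in the source may bear on it.

The series shares one core, present in compound 1 `COc1ccc(C(=O)/C=C/c2nc3ccccc3cc2-c2ccc(OC)cc2)cc1`, compound 2 `COc1ccc(-c2cc3ccccc3nc2/C=C/C(=O)c2ccc(N)cc2)cc1` and compound 3 `COc1ccc(-c2cc3ccccc3nc2/C=C/C(=O)c2ccc([N+](=O)[O-])cc2)cc1`, and the three differ only in the group on the carbonyl carbon. In a functional assay on SK-BR-3 cells (Homo sapiens) for antiproliferative activity, read by XTT assay, with a stated time of 72 h (on this read-out higher numbers stand for weaker inhibition and lower numbers for stronger inhibition), compound 1 gives 9280 nM, compound 2 gives 8560 nM, and compound 3 gives 590 nM. The step of a 1.1-fold lower number from compound 1 to compound 2 (0.04 log units; within the scatter) is small, while a 16-fold lower number from compound 1 to compound 3 (1.20 log units; beyond the scatter) and a 15-fold lower number from compound 2 to compound 3 (1.16 log units; beyond the scatter) are both large. Compound 3 therefore stands lowest of the three, with compound 2 nearest and compound 1 furthest, both beyond the scatter.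

Compound 4 `COc1ccc(-c2cc3ccccc3nc2/C=C/C(=O)c2cccs2)cc1` makes the change (thiophen-2-yl in place of 4-nitrophenyl on a carbonyl carbon). None of the three measured steps concerns this exchange: each of them swaps one substituent on the phenyl ring, and only the nitro-bearing compound 3 reaches a low number, whereas compound 1 and compound 2, which lack the nitro group, sit far higher. Compound 4 also carries no nitro group. The step of an 8.5-fold higher number from compound 3 to compound 4 (0.93 log units; beyond the scatter) is therefore expected to move the number upward, back toward the range of compound 1 and compound 2, although no ring of this kind has been tested here and the estimate is correspondingly wide. In this assay compound 4 is estimated at 5000 nM, within 1500 nM to 16000 nM.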

Compound 4, half-maximal inhibitory concentration: 800 nM
The estimate for compound 4 lay 6.3-fold (0.80 log units) above the measured number; measured number outside the range, below it.
By their numbers in this assay, from the lowest: compounds 3 and 4 (each within the scatter of the next); then compounds 2 and 1 (each within the scatter of the next).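

In this assay, a low number on this carbonyl carbon no longer belongs to the nitro-bearing compound alone: a 1.4-fold higher number from compound 3 to compound 4 (0.13 log units; within the scatter), so thiophen-2-yl, a five-membered aromatic ring with no nitro group, sits level with 4-nitrophenyl. The same ring stands well apart from the other two phenyl groups, with an 11-fold lower number from compound 2 to compound 4 (1.03 log units; beyond the scatter) and a 12-fold lower number from compound 1 to compound 4 (1.06 log units; beyond the scatter), which splits the series into a low pair, compound 3 and compound 4, and a high pair, compound 1 and compound 2, and shows that a nitro group is not required for membership of the low pair. No independent measurement accounts for why two such different groups fall together here.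

The compounds shown leave open whether the low number follows the sulfur or the five-membered ring as such, a question that a furan ring or a pyridine ring on the same carbonyl carbon could address. They also leave open whether other substituents on the phenyl ring, such as a nitrile or a carboxylic acid, would join the low pair or the high pair.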